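The source may report more compounds than this note shows. Statements on the series, on what has been measured and on what is new or still open speak of the compounds shown alone.

Measured in an ADME assay on CCRF-HSB-2 cells (Homo sapiens) for cytotoxicity, with a stated time of 7 days; on this read-out higher numbers stand for lower toxicity in this test and lower numbers for higher toxicity in this test:
compound 1 `CNc1nc(N)nc2c1ncn2/C=C1/CC1(CO)CO`: > 20000 nM
compound 2 `Nc1nc(OCC(F)(F)F)c2ncn(/C=C3/CC3(CO)CO)c2n1`: > 20000 nM

Compound 2 gives > 20000 nM, which is a limit of the assay and not a number. It shares that position with compound 1, as the limit of > 20000 nM in this assay, at which 2 of the 2 values shown sit, shows, so neither compound has a readable value.

Compound 3 `CC(C)CSc1nc(N)nc2c1ncn2/C=C1/CC1(CO)CO` keeps the shared core but has isobutylsulfanyl in place of 2,2,2-trifluoroethoxy on an aromatic carbon. Going by the values given here, the only measured step that bears on this change is a step that the two limits leave unreadable from compound 1 to compound 2, a swap of groups at the same place. It offers no size to carry over, so no step beyond the scatter is expected in this assay, and no direction can be favoured. The estimated step is a number no higher from compound 2 to compound 3 (the limit leaves the size open). For compound 3 the expected value is 20000 nM, with an estimated range from 7000 nM to 40000 nM.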

Compound 3, half-maximal cytotoxic concentration: 60000 nM
Compound 3: the middle estimate sits 3.0-fold (0.48 log units) below what was measured, outside the stated range (above it).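

Compound 1 and compound 2 stop at a limit of the assay, so no step from either of them to compound 3 can be read: the limit of > 20000 nM in this assay, at which 2 of the 3 values shown sit.

On these data alone, whether methylamino, 2,2,2-trifluoroethoxy and isobutylsulfanyl truly differ in this assay, and by how much, stays open.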